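The source may report more compounds than this note shows. Statements on the series, on what has been measured and on what is new or still open speak of the compounds shown alone.

Measured so far in a functional assay on the whole organism with Rattus norvegicus as the target; on this read-out lower numbers stand for an effect already at smaller amounts and higher numbers for an effect only at larger amounts of compound:
- compound 1 `CCOCCOC(=O)C(=O)Nc1nc(-c2cc(Br)no2)cs1` gives 11 mg/kg
- compound 2 `COCCOC(=O)C(=O)Nc1nc(-c2cc(Br)no2)cs1` gives 7 mg/kg
- compound 3 `CCOCCOC(=O)C(=O)Nc1nc(-c2cc(Br)no2)c(CC)s1` gives 3 mg/kg

Compound 1 is the reference point here, and two steps lead away from it. Hydrogen in place of methyl on a saturated chain carbon gives a change within the scatter (a 1.6-fold lower number from compound 1 to compound 2 (0.20 log units; within the scatter)) and so does not separate the two compounds. Ethyl in place of hydrogen on an aromatic carbon gives a modest drop beyond the scatter (a 3.7-fold lower number from compound 1 to compound 3 (0.56 log units; beyond the scatter)).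

The next compound is compound 4 `CCOCCOC(=O)C(=O)Nc1nc(-c2cc(C)on2)cs1`, which exchanges one ring group for another on an aromatic carbon (5-methyl-1,2-oxazol-3-yl in place of 3-bromo-1,2-oxazol-5-yl on an aromatic carbon). Neither measured step bears directly on this exchange, since 3-bromo-1,2-oxazol-5-yl stays in place in compound 2 (7 mg/kg) and in compound 3 (3 mg/kg). The data therefore give no size or direction for it, and no step beyond the scatter is expected in this assay, though with wide uncertainty. The expected change is small (a 1.3-fold higher number from compound 1 to compound 4 (0.10 log units; within the scatter)). For compound 4 the estimated value is 14 mg/kg, with an expected range from 5 mg/kg to 40 mg/kg.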

Compound 4, dose for half-maximal effect: 1.3 mg/kg
Compound 4: the middle estimate sits 11-fold (1.03 log units) above what was measured; measured number below the stated range.
By their numbers in this assay, from the lowest: compound 4; then compound 3; then compounds 2 and 1 (each within the scatter of the next).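

In this assay the exchange on this aromatic carbon, next to the ring nitrogen, is far from neutral: 5-methyl-1,2-oxazol-3-yl in place of 3-bromo-1,2-oxazol-5-yl gives a clear change (an 8.5-fold lower number from compound 1 to compound 4 (0.93 log units; beyond the scatter)). The two groups are each one five-membered aromatic ring with the same counts of heavy atoms, hydrogen-bond donors and hydrogen-bond acceptors, so those counts do not separate them, yet the read-out does. No measurement at hand explains this difference.

The compounds shown leave open whether the change follows from methyl replacing bromine or from the ring being attached through a different ring carbon, as both change together in this single step. Also open, on these data alone, are how a phenyl ring would read at this place and whether the ethyl group of compound 3 would combine with 5-methyl-1,2-oxazol-3-yl.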